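Compound 2 to compound 4: methyl in place of chloro

A few compounds are considered here, and "the series" means these few. Any claim that something is new, unique, unknown or untested is made for them only; others in the source may bear on it.

In a functional assay on the whole organism for antagonist activity, with Mus musculus as the target (on this read-out lower numbers stand for an effect already at smaller amounts and higher numbers for an effect only at larger amounts of compound), compound 1 (`CCC(=O)N(c1ccc(Cl)cc1)C1CCCC1N(C)C`), which carries chloro, gives 0.2 mg/kg. Compound 2 (`CCC(=O)N(c1ccc(Cl)cc1)C1CCCCC1N(C)C`), also with chloro, gives 17 mg/kg, a much higher number than that of compound 1 and beyond the scatter. Compound 3 (`CCC(=O)N(c1ccc(C)cc1)C1CCCC1N(C)C`), which carries methyl, gives 10 mg/kg; 10 mg/kg (2 entries).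

Compound 4 (`CCC(=O)N(c1ccc(C)cc1)C1CCCCC1N(C)C`) follows from compound 2 by methyl in place of chloro on an aromatic carbon. With chloro compound 1 stands at 0.2 mg/kg and with methyl compound 3 stands at 10 mg/kg; 10 mg/kg (2 entries), so a higher number is expected. The data do not show how much of that gap carries over to the core of compound 2. In this assay the expected change is a modest rise, a 2.4-fold higher number from compound 2 to compound 4 (0.37 log units; beyond the scatter). For compound 4 the estimate is 40 mg/kg, with an expected range of 10 mg/kg to 200 mg/kg.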

Compound 4, dose for half-maximal effect: > 50 mg/kg
Compound 4 ended at the assay's limit; the forecaster's own chance of this, stated with the estimate: 25%; middle value at least 1.2-fold (0.09 log units) away from the limit.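

Compound 4 gives a limit and not a number (> 50 mg/kg) in this assay. Methyl in place of chloro at this position, seen so far only between compound 1 (0.2 mg/kg) and compound 3 (10 mg/kg; 10 mg/kg (2 entries)), also gives a higher number on the core of compound 2 (an at least 2.9-fold higher number from compound 2 to compound 4 (0.46 log units; beyond the scatter)). The size of this step is therefore bounded on one side only: the limit of > 50 mg/kg in this assay, at which 1 of the 4 values shown sits.

Still open, as far as these compounds go, is how far the number of compound 4 lies past the limit. Also open, from the compounds shown here alone, is how an amine or a methoxy group at this position would read on either core.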